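A few compounds are considered here, and "the series" means these few. Any claim that something is new, unique, unknown or untested is made for them only; others in the source may bear on it.

In a functional assay on HCT-116 cells (Homo sapiens) for antiproliferative activity, read by MTT assay, with a stated time of 48 h (a higher number here means a weaker inhibitor, a lower number a stronger inhibitor), compound 1 `Cc1cccc(-n2nncc2CN2C(=O)C3(C(C#N)=C(N)Oc4c3c3nc5ccccc5nc3c3ccccc43)c3ccccc32)c1` gives > 50000 nM, which is a limit of the assay and not a number. Compound 2 `Cc1cc(C)cc(-n2nncc2CN2C(=O)C3(C(C#N)=C(N)Oc4c3c3nc5ccccc5nc3c3ccccc43)c3ccccc32)c1` gives > 50000 nM in this assay, again a limit rather than a number. The step from compound 1 to compound 2, a step that the two limits leave unreadable from compound 1 to compound 2, is a methyl in place of hydrogen on an aromatic carbon; its size cannot be read because of the limit of > 50000 nM in this assay, at which 2 of the 2 values shown sit. Compound 2 therefore stands at the limit of this assay, with no measured number to place it.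

Compound 3 `N#CC1=C(N)Oc2c(c3nc4ccccc4nc3c3ccccc23)C12C(=O)N(Cc1cnnn1-c1ccc(Cl)c(Cl)c1)c1ccccc12` is not yet measured. It differs from compound 2 by 3,4-dichlorophenyl in place of 3,5-dimethylphenyl on an aromatic nitrogen of the five-membered aromatic ring, next to the ring nitrogen and next to the ring atom that bears a large group. Among the measured compounds shown here, no measured step exchanges one aryl group for another at this nitrogen, and the single step is unreadable. The expected step that the limit leaves unreadable from compound 2 to compound 3 in this assay thus rests on no readable precedent. Compound 3 is expected to give 60000 nM in this assay, with a range from 15000 nM to 250000 nM, most likely reported again only as a limit.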

Compound 3, half-maximal inhibitory concentration: > 50000 nM
Compound 3: only a limit was reported; the forecaster's own chance of this, stated with the estimate: 80%; the middle value does not contradict the limit.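

In this assay compound 3 gives > 50000 nM, a limit and not a number. No step among compound 1, compound 2 and compound 3 can be read, because all three stand at the same limit: the limit of > 50000 nM in this assay, at which 3 of the 3 values shown sit.

The compounds shown leave open which aryl group on the aromatic nitrogen, if any, would give a measurable value in this assay.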